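Chloro in Place of Methyl: Compound 2 to Compound 3

The source may hold more compounds than are shown below. What is called first, only, known or untested is meant among the compounds shown, and "the series" means these compounds.

Of the compounds shown here, two built on a shared core have been measured so far in a functional assay on NUGC-3 cells (Homo sapiens) for inhibition, read by sulforhodamine B assay; a lower number here means a stronger inhibitor of growth, a higher number a weaker inhibitor of growth. Compound 1, `Cc1ccc(CN2CC=C(CCC(=O)NO)C2=O)cc1`, gives 4280 nM in this assay. Compound 2, `Cc1ccc(CCCCN2CC=C(CCC(=O)NO)C2=O)cc1`, gives 3530 nM in this assay. Compound 2 carries the lowest of the two numbers, but its nearest neighbour, compound 1, lies within the scatter of it, so the two values show no difference that can be read as real.

Compound 3, `O=C(CCC1=CCN(CCCCc2ccc(Cl)cc2)C1=O)NO`, has not yet been measured. It differs from compound 2 in one place: chloro in place of methyl on an aromatic carbon. Going by the values given here, no step between two measured compounds shows what this change does, and the two measured compounds differ from each other at another place altogether. The account therefore rests on compound 2 alone. The step is expected to be small, in either direction, and not beyond the scatter, a 1.0-fold lower number from compound 2 to compound 3 (0.00 log units; within the scatter). Compound 3 is estimated at 3500 nM in this assay, with a range from 1500 nM to 8000 nM.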

Compound 3, concentration for 50% growth inhibition: 3530 nM
The estimate for compound 3 lay 1.0-fold (0.00 log units) below the measured number, within the range that was stated.
By their numbers in this assay, from the lowest: compounds 2, 3 and 1 (each within the scatter of the next).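

Chloro in place of methyl on an aromatic carbon, para to a large group, brings no change at the digits printed from compound 2 to compound 3 (within the scatter) in this assay for this pair. Going by these compounds alone, this is the first reading at this position, since compounds 1 and 2 differ from each other elsewhere and say nothing about the group carried on the ring. Within this one pair, then, 4-methylphenyl and 4-chlorophenyl cannot be told apart in growth inhibition, and nothing available offers an explanation for that result.

The compounds shown leave open whether this position answers to groups of another kind, such as an amine, a carboxylic acid, a methoxy group or a trifluoromethyl group, any of which might move the number beyond the scatter where chloro and methyl do not. They also leave open whether the exchange of methyl for chloro would read the same on the shorter chain of compound 1, as the step is known only on the chain of compound 2.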